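Changing One Aromatic Group on Compound 2

The source may report more compounds than this note shows. Statements on the series, on what has been measured and on what is new or still open speak of the compounds shown alone.

Of the compounds shown here, two have been measured so far in a functional assay on HeLa cells (Homo sapiens) for cytotoxicity, read by MTT assay, with a stated time of 72 h; on this read-out higher numbers stand for weaker inhibition and lower numbers for stronger inhibition. Compound 1 `Cn1ccc2c(Oc3ccc(NC(=O)c4cc5cccnc5n(-c5ccc(C(F)(F)F)c(Cl)c5)c4=O)cc3)ncnc21` gives 289000 nM, while compound 2 `Cn1ccc2c(Oc3ccc(NC(=O)c4cc5cccnc5n(-c5ccc(Cl)cc5)c4=O)cc3F)ncnc21` gives 43900 nM. Compound 2 therefore holds the lower of the two numbers, and the gap lies beyond the scatter. These two structures differ in more than one place, so the gap cannot be pinned on any single change.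

Compound 3 `Cn1ccc2c(Oc3ccc(NC(=O)c4cc5cccnc5n(-c5ccc(C(F)(F)F)c(Cl)c5)c4=O)cc3F)ncnc21` differs from compound 2 in one place, with 3-chloro-4-(trifluoromethyl)phenyl in place of 4-chlorophenyl on an aromatic nitrogen. Among the measured compounds shown here, compound 3 shares this new group with compound 1, but no measured pair isolates the swap, so any forecast is uncertain. A modest move towards weaker inhibition is expected because compound 1 with the same group gives 289000 nM. The expected change is a 2.3-fold higher number from compound 2 to compound 3 (0.36 log units; beyond the scatter), which would sit only a little beyond the scatter. For compound 3 the estimated value is 100000 nM, with an expected range from 30000 nM to 300000 nM.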

Compound 3, half-maximal inhibitory concentration: 156000 nM
For compound 3 the middle estimate is 1.6-fold (0.19 log units) below the measured one, within the range that was stated.
By their numbers in this assay, from the lowest: compound 2; then compounds 3 and 1 (each within the scatter of the next).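

In this assay, replacing 4-chlorophenyl with 3-chloro-4-(trifluoromethyl)phenyl on the aromatic nitrogen gives a 3.6-fold higher number from compound 2 to compound 3 (0.55 log units; beyond the scatter), a modest move towards weaker inhibition. Among the compounds shown here, this is the first pair to isolate this swap, and it shows that the group on this nitrogen can shift the read-out by more than the usual scatter, even though the entering group adds no hydrogen-bond donors, acceptors or charge. The other new pair isolates a second change, fluoro in place of hydrogen on an aromatic carbon, and gives a 1.9-fold lower number from compound 1 to compound 3 (0.27 log units; within the scatter), so with 3-chloro-4-(trifluoromethyl)phenyl in place this fluoro makes no readable difference. Nothing measured here explains why the swap on the nitrogen changes the number.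

The swap alters two features of the ring at once, so these compounds cannot say whether the added chlorine, the trifluoromethyl group or their combination accounts for the step. Nor do they show how this position would respond to a plain phenyl, a methoxyphenyl or an aminophenyl group, or whether the fluoro stays without a readable effect when 4-chlorophenyl sits on the nitrogen.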